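The source may hold more compounds than are shown below. What is called first, only, known or untested is meant among the compounds shown, and "the series" means these compounds.

Compound 1 `COc1cccc(NC(=O)Nc2ccc(Oc3ncnc4[nH]ncc34)cc2)c1`: 82000 nM
Compound 2 `Cc1cccc(NC(=O)Nc2ccc(Oc3ncnc4[nH]ncc34)cc2)c1C`: 98800 nM

Both numbers come from an assay on isolated protein for inhibition of vascular endothelial growth factor receptor 2 (Danio rerio), read by fluorescence and microscopy, with a stated time of 33 h; a lower number here means a stronger inhibitor, a higher number a weaker inhibitor. Compound 2 has the higher of the two, yet the step of a 1.2-fold higher number from compound 1 to compound 2 (0.08 log units; within the scatter) lies within the scatter, so the two compounds cannot be told apart. Compound 3 `O=C(Nc1ccc(Oc2ncnc3[nH]ncc23)cc1)c1ccc(Br)cc1` differs from compound 2 by 4-bromophenyl in place of (2,3-dimethylphenyl)amino on a carbonyl carbon. For the measured compounds named here, no measured step covers this kind of change; the only step in hand barely moved the number. Compound 3 is therefore expected to stay close to the measured pair, with a 1.1-fold lower number from compound 2 to compound 3 (0.04 log units; within the scatter) seen as no step beyond the scatter. In this assay compound 3 is expected at 90000 nM, within 30000 nM to 300000 nM.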

Compound 3, half-maximal inhibitory concentration: 74700 nM
Compound 3: middle estimate off by 1.2-fold (0.08 log units), on the high side; measured number inside the range.
By their numbers in this assay, from the lowest: compounds 3, 1 and 2 (each within the scatter of the next).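

In this assay, putting 4-bromophenyl on the carbonyl carbon gives a 1.3-fold lower number from compound 2 to compound 3 (0.12 log units; within the scatter) and a 1.1-fold lower number from compound 1 to compound 3 (0.04 log units; within the scatter). Unlike the earlier pair, which both keep an amino link, compound 3 has a carbon-bound aromatic ring there and lacks the hydrogen-bond donor counted in the leaving group, yet it cannot be told apart from compound 1 or compound 2. No available evidence bears on this result. From the compounds shown here alone, it remains open whether a carboxylic acid or a saturated amine on the carbonyl carbon would give a number beyond the scatter.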